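The source may hold more compounds than are shown below. What is called first, only, known or untested is meant among the compounds shown, and "the series" means these compounds.

Compound 1, `COc1ccccc1/C=C(\C(=O)c1ccc(Br)cc1)S(=O)(=O)c1ccc(C)cc1`, and compound 2, `COc1ccccc1/C=C(\C(=O)c1ccc(Cl)cc1)S(=O)(=O)c1ccc(C)cc1`, share a core and differ only at one aromatic carbon. In a functional assay on DU-145 cells (Homo sapiens) for inhibition, read by trypan blue exclusion, with a stated time of 96 h (a higher number here means a weaker inhibitor of growth, a lower number a stronger inhibitor of growth), compound 1 gives 1000 nM, and in this assay compound 2 gives 1000 nM. The change between them, (chloro in place of bromo on an aromatic carbon), produced no change at the digits printed from compound 1 to compound 2 (within the scatter).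

Compound 3, `O=C(/C(=C\c1ccc(O)c([N+](=O)[O-])c1)Sc1ccccc1Br)c1ccc(Br)cc1`, is built on a different core; how its core differs from that of compound 1 is not broken down here. In this assay, among the compounds with values here, compound 3 gives 10000 nM, the highest of the three numbers so far and a step beyond the scatter from both compound 1 and compound 2.

Compound 4, `O=C(/C(=C\c1ccc(O)c([N+](=O)[O-])c1)Sc1ccccc1Br)c1ccc(Cl)cc1`, has not yet been measured. It differs from compound 3 by chloro in place of bromo on an aromatic carbon, the same change that turned compound 1 into compound 2, at a place described in the same words. Since that earlier change left the number unmoved, the step from compound 3 to compound 4 is expected to be no change at the digits printed from compound 3 to compound 4 (within the scatter), resting on the flat result of no change at the digits printed from compound 1 to compound 2 (within the scatter). Compound 4 is therefore estimated to give 10000 nM in this assay, between 5000 nM and 20000 nM.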

Compound 4, concentration for 50% growth inhibition: 25000 nM
For compound 4 the middle estimate is 2.5-fold (0.40 log units) below the measured one; the measured number lies above the stated range.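

In this assay, chloro in place of bromo gives a 2.5-fold higher number from compound 3 to compound 4 (0.40 log units; beyond the scatter), a modest step, while on the other core the same change gave no change at the digits printed from compound 1 to compound 2 (within the scatter). Set side by side, the two results cannot be told apart: the same change on two cores in this assay, no change at the digits printed (within the scatter) from compound 1 to compound 2 and a 2.5-fold higher number (0.40 log units; beyond the scatter) from compound 3 to compound 4, 2.5-fold (0.40 log units) apart, within the scatter of two such steps. As far as these two pairs can tell, the change carries from one core to the other without a clear difference, but one pair per core does not show that its effect is truly the same on both, and it does not rule out a small difference hidden in the scatter.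

On these data alone, only bromo and chloro appear at this place on the ring, so it remains open how the growth read-out would respond to fluoro, an amine or a carboxylic acid there. It also remains open whether the swap would behave in the same way on any core beyond the two shown.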